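From Ethyl to Thiophen-2-yl: A Cytotoxicity Estimate

The source may hold more compounds than are shown below. What is called first, only, known or untested is meant among the compounds shown, and "the series" means these compounds.

In a functional assay on SH-SY5Y cells (Homo sapiens) for cytotoxicity, read by MTT assay, with a stated time of 72 h (on this read-out lower numbers stand for stronger inhibition and higher numbers for weaker inhibition), compound 1 `CCC[S+]([O-])CCCCN=C=S` gives 7660 nM. Compound 3 `[O-][S+](CCCCN=C=S)Cc1ccccn1` gives 7830 nM, which is level with compound 1 within the usual scatter of repeated measurements. Compound 2 `COc1ccc(C[S+]([O-])CCCCN=C=S)cc1` gives 2790 nM, a number lower than the other two by more than that scatter, and so stronger inhibition.

Compound 4 `[O-][S+](CCCCN=C=S)Cc1cccs1` has not yet been measured. It carries thiophen-2-yl in place of ethyl on a saturated chain carbon bound to a sulfur.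

Within the data shown here, no measured pair differs in just one place, so the three values are the only guide. Compound 2 and compound 3 both carry a ring that compound 1 lacks, yet only compound 2 at 2790 nM stands apart, while compound 3 at 7830 nM does not. A ring alone therefore does not settle the outcome. A modest fall in the number is expected, perhaps none beyond the scatter. The expected change is a 1.8-fold lower number from compound 1 to compound 4 (0.26 log units; within the scatter). Compound 4 is estimated at 4200 nM, with an expected range from 1900 nM to 9000 nM.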

Compound 4, half-maximal inhibitory concentration: 5310 nM
Compound 4: the middle estimate sits 1.3-fold (0.10 log units) below what was measured; the range from low to high includes it.
By their numbers in this assay, from the lowest: compounds 2, 4, 1 and 3 (each within the scatter of the next, the first and the last beyond it).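

On the saturated chain carbon bound to a sulfur, thiophen-2-yl in place of ethyl gives a 1.4-fold lower number from compound 1 to compound 4 (0.16 log units; within the scatter) in this assay. Among these compounds, this is the first comparison here in which only one place differs, and it shows that this five-membered aromatic ring can replace the small ethyl group with no difference that stands clear of the usual scatter. Nothing available explains this outcome or links it to any property of either group.

Still open, as far as these compounds go, is whether a group of another kind at this place, such as an amine, a carboxylic acid or a longer alkyl chain, would move the number beyond the scatter. Also open, from the compounds shown here alone, is whether the same exchange would give a similar result on a different core.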